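This account rests on a few compounds, and the source may have more. Where it says the series, first, only, none or still open, it means among the compounds named here.

Four related compounds are in view here, all tested in a functional assay on A549 cells (Homo sapiens) for cytotoxicity, read by MTT assay, with a stated time of 48 h; a lower number here means a stronger inhibitor, a higher number a weaker inhibitor. Compound 1 `COc1ccc(-c2c[nH]c(=O)n2-c2cc(OC)c(OC)c(OC)c2)cc1OC` gives > 50000 nM, which is a limit of the assay and not a number. Compound 2 `COc1cc(NC(=O)n2cc(-c3ccc(O)cc3)n(-c3cc(OC)c(OC)c(OC)c3)c2=O)cc(OC)c1OC` gives a true number, 2500 nM, the only one so far. Compound 3 `COc1cc(-n2c(-c3ccccc3)cn(C(C)=O)c2=O)cc(OC)c1OC` gives > 50000 nM, again a limit and not a number. Compound 3 thus stands at the limit of > 50000 nM in this assay, at which 2 of the 3 values shown sit, so its true strength in this assay is not known.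

Compound 4 `COc1cc(-n2c(-c3ccc([N+](=O)[O-])cc3)cn(C(C)=O)c2=O)cc(OC)c1OC` differs from compound 3 in one place, where phenyl becomes 4-nitrophenyl, with nitro in place of hydrogen on an aromatic carbon, para to a large group: nitro in place of hydrogen on an aromatic carbon. Among the compounds with values here, no measured pair shows what this change does in this assay, so the expectation has little to rest on. The starting point is only a limit, which means that a small gain could not be sized against compound 3. A large gain is not expected from this single change. The expected step of an at least 1.2-fold lower number from compound 3 to compound 4 (0.09 log units; that floor lies within the scatter) is small and towards stronger inhibition, and the result may again be only a limit. For compound 4 the estimated value is 40000 nM, with an expected range of 8000 nM to 100000 nM.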

Compound 4, half-maximal inhibitory concentration: 49600 nM
Beside the measured number, compound 4's estimate is 1.2-fold (0.09 log units) below it; low and high end bracket the measured number.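

In this assay, replacing hydrogen with nitro on the phenyl ring gives a number no higher from compound 3 to compound 4 (the limit leaves the size open), so this place on the ring tolerates a nitro group with no loss of strength visible in the data. Compound 3 gives > 50000 nM, which is a limit of the assay and not a number. On these data alone, compound 4 supplies a true number where compound 3 has none, but the size of any gain stays unknown, and compound 4 still lies close to the top of what the assay can read: the limit of > 50000 nM in this assay, at which 2 of the 4 values shown sit.

The compounds shown leave open whether the result is particular to nitro or whether a different group at the same place, such as an amine or a carboxylic acid, would give a clearly lower number. They also leave open what nitro would do on a starting compound with a true number of its own, where a change in either direction could be sized.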